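Working notes: cytotoxicity across three close analogues

The source may hold more compounds than are shown below. What is called first, only, known or untested is meant among the compounds shown, and "the series" means these compounds.

Compound 1 `Fc1cccc(F)c1Cc1cnc(Nc2ccc(Oc3ccncc3)c(Cl)c2)o1` and compound 2 `Fc1cccc(F)c1Cc1cnc(Nc2ccc(-c3cccnc3)c(Cl)c2)o1` share one core and differ only at a single aromatic carbon. In an ADME assay on MT2 cells (Homo sapiens) for cytotoxicity, read by MTT assay (on this read-out lower numbers stand for higher toxicity in this test and higher numbers for lower toxicity in this test), compound 1 gives 21000 nM, and in this assay compound 2 gives 8900 nM. For the measured compounds named here, the single measured step, a 2.4-fold lower number from compound 1 to compound 2 (0.37 log units; beyond the scatter), moves the read-out downward. Going by the values given here, on the numbers so far compound 2 therefore holds the lowest value of the two, with compound 1 as its nearest neighbour at a distance beyond the scatter.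

Compound 3 `OCc1ccc(Nc2ncc(Cc3c(F)cccc3F)o2)cc1Cl` has not yet been measured. It differs from compound 2 by hydroxymethyl in place of pyridin-3-yl on an aromatic carbon. Among the compounds with values here, no measured step replaces a ring with a hydroxymethyl, so the one available step, a 2.4-fold lower number from compound 1 to compound 2 (0.37 log units; beyond the scatter), bears on it only loosely: it shows that an exchange at this carbon can shift the read-out by a modest amount beyond the scatter. For compound 3 a modest step in the opposite direction is expected, back towards or past the value of compound 1. Compound 3 is thus expected to give 20000 nM in this assay, within a range of 7000 nM to 60000 nM. This estimate is expected to correspond to a 2.2-fold higher number from compound 2 to compound 3 (0.35 log units; beyond the scatter).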

Compound 3, half-maximal cytotoxic concentration: 90000 nM
For compound 3 the middle estimate is 4.5-fold (0.65 log units) below the measured one, and the stated range ends below it.
By their numbers in this assay, from the lowest: compound 2; then compound 1; then compound 3.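

In this assay, the exchange at this aromatic carbon, ortho to a chloro group, has a larger reach than the first pair suggested: hydroxymethyl in place of pyridin-3-yl gives a 10-fold higher number from compound 2 to compound 3 (1.00 log units; beyond the scatter), and hydroxymethyl in place of (pyridin-4-yl)oxy gives a 4.3-fold higher number from compound 1 to compound 3 (0.63 log units; beyond the scatter). Both steps point the same way, so among these three compounds the one group without a ring carries the highest number, and both ring-bearing groups sit lower, with no compound shown going against this, though the pattern rests on a single hydroxymethyl example. Nothing available accounts for the size of these steps.

The exchange from compound 2 to compound 3 removes a six-membered aromatic ring and brings in a hydrogen-bond donor at once, and the compounds shown do not separate the two changes. On these data alone, whether the higher number goes with the hydroxyl or simply with the absence of a ring stays open; a plain methyl, an aminomethyl, a carboxylic acid or a longer chain ending in a hydroxyl at this carbon would bear on that question.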